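From 4-methylphenyl to 3,4-dimethylphenyl at compound 4

The source may hold more compounds than are shown below. What is called first, only, known or untested is meant among the compounds shown, and "the series" means these compounds.

In a functional assay on HeLa cells (Homo sapiens) for inhibition, read by sulforhodamine B assay (a higher number here means a weaker inhibitor, a lower number a stronger inhibitor), compound 3 `Cc1ccc(NC2=CC(=O)c3c(nc4n3[C@H]3OC[C@@H](O)[C@H]3OC4)C2=O)cc1` gives 6590 nM and lies within the scatter of compound 1 `O=C1C(Nc2ccc(I)cc2)=CC(=O)c2c1nc1n2[C@H]2OC[C@@H](O)[C@H]2OC1` at 4010 nM on the numbers shown. Compound 2 `O=C1C(NC2CCCC2)=CC(=O)c2c1nc1n2[C@H]2OC[C@@H](O)[C@H]2OC1` is reported as > 16000 nM and that value is a limit. The change to compound 4 `Cc1ccc(NC2=CC(=O)c3c(nc4n3[C@H]3OC[C@@H](O)[C@H]3OC4)C2=O)cc1C` is methyl in place of hydrogen on an aromatic carbon, ortho to a methyl group and meta to a large group methyl in place of hydrogen on an aromatic carbon and it keeps the aromatic ring. The nearest measured change is a 1.6-fold higher number from compound 1 to compound 3 (0.22 log units; within the scatter) and it involves the same ring. Exchanging that ring for cyclopentyl gave the larger steps, an at least 3.9-fold higher number from compound 1 to compound 2 (0.60 log units; beyond the scatter) and an at least 2.4-fold lower number from compound 2 to compound 3 (0.38 log units; beyond the scatter) and both rest on the limit. No step beyond the scatter is therefore expected in this assay and the estimate is a 1.2-fold lower number from compound 3 to compound 4 (0.08 log units; within the scatter) overall. Compound 4 is expected at 5500 nM with an estimated range of 2500 nM to 12000 nM as the working range.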

Compound 4, half-maximal inhibitory concentration: 4320 nM
The estimate for compound 4 lay 1.3-fold (0.10 log units) above the measured number; measured number inside the range.
By their numbers in this assay, from the lowest: compounds 1, 4 and 3 (each within the scatter of the next). At a limit, above all of these: compound 2.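

In this assay, methyl in place of hydrogen on the aromatic carbon ortho to a methyl group gives a 1.5-fold lower number from compound 3 to compound 4 (0.18 log units; within the scatter), so this position accepts a second methyl without a step beyond the scatter. The 3,4-dimethylphenyl group also gives a 1.1-fold higher number from compound 1 to compound 4 (0.03 log units; within the scatter), which adds a third aromatic group within the scatter of the others. The step from the cyclopentyl compound, an at least 3.7-fold lower number from compound 2 to compound 4 (0.56 log units; beyond the scatter), keeps the aromatic ring apart from cyclopentyl but rests on a limit: the limit of > 16000 nM in this assay, at which 1 of the 4 values shown sits.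

Open, going by these compounds, is what a methoxy group, an amine or a carboxylic acid would give on this aromatic carbon. Also open, on these data alone, is whether any group here produces a step beyond the scatter from compound 3.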